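Removing the methyl from the thiazole of compound 1

The source may report more compounds than this note shows. Statements on the series, on what has been measured and on what is new or still open speak of the compounds shown alone.

Compounds measured so far:
compound 1 `COc1cc(NCc2scnc2C)ccc1-c1cnco1` gives 73700 nM
compound 2 `COc1ccc(-c2cnco2)cc1NCc1cccs1` gives 53800 nM
compound 3 `COc1cc(/N=C/c2ccc(F)cc2)ccc1-c1cnco1` gives 325000 nM

Of the compounds shown here, three have been tested in an ADME assay on Vero cells (Chlorocebus sabaeus) for cytotoxicity, read by MTT assay, with a stated time of 96 h; on this read-out lower numbers stand for higher toxicity in this test and higher numbers for lower toxicity in this test. Among these numbers compound 1 stands second highest. Its nearest neighbour is compound 2, whose number is lower but within the scatter, so the two cannot be told apart on this evidence. The furthest is compound 3, whose number is higher by a margin beyond the scatter. Among the measured compounds shown here, no pair of these three differs in a single place, so no step between measured compounds can be drawn.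

Compound 4 `COc1cc(NCc2cncs2)ccc1-c1cnco1` is not yet measured in this assay. It differs from compound 1 in one place: hydrogen in place of methyl on an aromatic carbon. The change removes only a small group from the ring that carries the amine linker, and the core is otherwise the same.

For the measured compounds named here, with no measured step of the same kind to rest on, the expectation for compound 4 is a step of a 1.1-fold lower number from compound 1 to compound 4 (0.02 log units; within the scatter) in this assay, which is to say none beyond the scatter. Compound 4 is therefore estimated at 70000 nM, with a range from 35000 nM to 140000 nM.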

Compound 4, half-maximal cytotoxic concentration: 232000 nM
The estimate for compound 4 lay 3.3-fold (0.52 log units) below the measured number; measured number above the stated range.
By their numbers in this assay, from the lowest: compounds 2 and 1 (each within the scatter of the next); then compounds 4 and 3 (each within the scatter of the next).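

Going from the 4-methyl-1,3-thiazol-5-yl group to the 1,3-thiazol-5-yl group gives a 3.1-fold higher number from compound 1 to compound 4 (0.50 log units; beyond the scatter) in this assay, a modest step but one beyond the scatter. Among the compounds shown here, it shows that this position, on the aromatic carbon next to the ring nitrogen, is not silent in this test: losing a single methyl, one carbon with no hydrogen-bond donor or acceptor, is enough to move the number towards lower toxicity, which no earlier pair could show, as none of them differed in one place. Nothing measured here accounts for the step.

With hydrogen and methyl the only two groups shown on this carbon, it remains open whether the number follows the size of the group or whether something particular to methyl is at work, and an ethyl group, a chlorine atom, an amine or a carboxylic acid at the same place would each bear on that. As far as these compounds go, it is also open whether hydrogen in place of methyl would give a step of this size on another ring or with another linker to the shared core, as this single step is all that speaks to the change.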